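Amine side chains: replacing methyl with phenyl on the piperazine

The compounds below may be only part of what the source reports. "The series", "measured", "known", "first", "only" and "open" are said of these compounds alone.

Values in a functional assay on Hs 683 cells (Homo sapiens) for inhibition, read by colorimetric assay and MTT assay, with a stated time of 72 h; on this read-out lower numbers stand for stronger inhibition and higher numbers for weaker inhibition:
Compound 1 `C/C1=C\CC[C@@]2(C)O[C@@H]2[C@H]2OC(=O)[C@@H](CN3CCCC3)[C@@H]2C[C@H]1O`: 15000 nM
Compound 2 `C/C1=C\CC[C@@]2(C)O[C@@H]2[C@H]2OC(=O)[C@@H](CN3CCN(C)CC3)[C@@H]2C[C@H]1O`: 33000 nM
Compound 3 `C/C1=C\CC[C@@]2(C)O[C@@H]2[C@H]2OC(=O)[C@@H](CN(C)CCN(C)C)[C@@H]2C[C@H]1O`: 9000 nM

Compound 2 has the highest number of the three, and its gaps to the other two compounds both lie beyond the scatter. The measured steps are a 2.2-fold higher number from compound 1 to compound 2 (0.34 log units; beyond the scatter) and a 3.7-fold lower number from compound 2 to compound 3 (0.56 log units; beyond the scatter). The remaining step, a 1.7-fold lower number from compound 1 to compound 3 (0.22 log units; within the scatter), shows that the other two compounds cannot be separated.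

The next compound is compound 4 `C/C1=C\CC[C@@]2(C)O[C@@H]2[C@H]2OC(=O)[C@@H](CN3CCN(c4ccccc4)CC3)[C@@H]2C[C@H]1O`. Its change from compound 2 is phenyl in place of methyl on an amine nitrogen in a ring, which is phenyl in place of methyl on an amine nitrogen in a ring. Among the compounds with values here, no measured step makes this exchange, since all three replace the whole amine group on the saturated chain carbon. Within the data shown here, the data also include no compound bearing phenyl. These steps therefore serve only as a gauge of size, and all of them are modest or smaller.

Compound 2 stands at the top of the measured range with 33000 nM, so a modest move to a lower number is expected in this assay, though the direction is weakly supported. The expected step is a 1.9-fold lower number from compound 2 to compound 4 (0.29 log units; within the scatter). The estimate for compound 4 is 17000 nM, with an expected range from 6000 nM to 45000 nM.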

Compound 4, half-maximal inhibitory concentration: 22000 nM
Estimate against measurement, compound 4: 1.3-fold (0.11 log units) below; the range from low to high includes it.
By their numbers in this assay, from the lowest: compounds 3, 1, 4 and 2 (each within the scatter of the next, the first and the last beyond it).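

In this assay, the exchange on the piperazine nitrogen gives a 1.5-fold lower number from compound 2 to compound 4 (0.18 log units; within the scatter), so a phenyl, with its six-membered aromatic ring of carbon only, in place of methyl does not separate compound 4 from compound 2. Within the data shown here, this is the first reading of a change on an amine nitrogen in a ring, three ring bonds from the ring atom that bears a large group, with the rest of the amine group left intact; the earlier steps each replaced the whole amine group, and one of them, a 3.7-fold lower number from compound 2 to compound 3 (0.56 log units; beyond the scatter), lies beyond the scatter. At this place, a step from 1 to 6 heavy atoms therefore leaves the read-out within the scatter, and no measured property of these compounds bears on the reason for this result.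

Going by these compounds, whether this holds for other groups at the same nitrogen remains open, for example benzyl, a longer chain ending in phenyl, or a phenyl carrying a carboxylic acid. Also open, on these data alone, is whether a plain hydrogen on that nitrogen would stay within the scatter of compound 2 and compound 4.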